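Adding a bromo group to compound 2

The source may hold more compounds than are shown below. What is called first, only, known or untested is meant among the compounds shown, and "the series" means these compounds.

Of the compounds shown here, three sharing one core have been tested in a functional assay on the whole organism (strain albino) for inhibition, with Rattus norvegicus as the target, read by paw edema, with a stated time of 30 min, at a dose of 100 mg/kg by the oral route; on this read-out lower numbers stand for less inhibition and higher numbers for more inhibition at the one dose given (going by the name of the read-out). Compound 1 `Cc1ccc(NCc2nc3ccc(Br)cc3[nH]2)cc1` gives 7.6%. Compound 2 `Clc1cccc(NCc2nc3ccccc3[nH]2)c1` gives 15.3%, the highest of the three, though its nearest neighbour compound 1 and its furthest neighbour compound 3 both lie within the scatter of it. Compound 3 `c1ccc(NCc2nc3ccccc3[nH]2)cc1` gives 7.6%. Among the measured compounds shown here, the single measured step, a number 7.7 percentage points lower from compound 2 to compound 3 (within the scatter), stays within the scatter. Compound 4 `Clc1cccc(NCc2nc3ccc(Br)cc3[nH]2)c1` differs from compound 2 by bromo in place of hydrogen on an aromatic carbon. For the measured compounds named here, no measured step changes the bromo group alone; compound 1, which carries it, and compound 3, which does not, show the same value. The step from compound 2 to compound 4 in this assay is therefore expected to be a number 3.3 percentage points lower from compound 2 to compound 4 (within the scatter), within the scatter. Compound 4 is estimated at 12%, between 0% and 30%.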

Compound 4, a percentage reported as inhibition, in the whole organism at one dose (the size of the read-out at that dose, not a potency): 7.6%
For compound 4 the middle estimate is 4.4 percentage points above the measured one; low and high end bracket the measured number.
By their numbers in this assay, from the lowest: compounds 1, 3, 4 and 2 (each within the scatter of the next).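

In this assay, the bromo group on the six-membered aromatic ring of carbon only now has its first direct reading, a single swap for hydrogen: a number 7.7 percentage points lower from compound 2 to compound 4 (within the scatter). At this dose, that step cannot be told apart from repeat-measurement noise, so these compounds show no clear effect of bromo at this position. Nothing available here offers an explanation for the result. Open, from the compounds shown here alone, is whether a different group at the same place, such as an amine or a carboxylic acid, would give a step beyond the scatter. Also open, going by these compounds, is how bromo would read at other doses.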